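Nitro for trifluoromethyl on the benzyl ether of compound 2

A few compounds are considered here, and "the series" means these few. Any claim that something is new, unique, unknown or untested is made for them only; others in the source may bear on it.

Measured so far in a functional assay on A549 cells (Homo sapiens) for antiproliferative activity, read by MTT assay, with a stated time of 72 h; on this read-out lower numbers stand for stronger inhibition and higher numbers for weaker inhibition:
compound 1 `FC(F)(F)c1ccc(COc2cccc(Nc3ncnc4cc5c(cc34)OCCOCCOCCO5)c2)cc1` gives 24900 nM
compound 2 `FC(F)(F)c1ccc(COc2ccc(Nc3ncnc4cc5c(cc34)OCCOCCOCCOCCO5)cc2)cc1` gives 8560 nM
compound 3 `FC(F)(F)c1ccc(COc2ccc(Nc3ncnc4cc5c(cc34)OCCOCCO5)cc2)cc1` reaches only the limit > 100000 nM, a boundary of the assay rather than a number the limit of > 100000 nM in this assay, at which 1 of the 3 values shown sits.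

Of the two numbers shown, compound 2 sits lowest; compound 1 stands higher by a gap beyond the scatter, but the two differ in more than one place, so no single step is drawn between them. Compound 4 `O=[N+]([O-])c1ccc(COc2ccc(Nc3ncnc4cc5c(cc34)OCCOCCOCCOCCO5)cc2)cc1` carries the change nitro in place of trifluoromethyl on an aromatic carbon relative to compound 2. For the measured compounds named here, no measured pair tests this change, so in this assay a step of modest size, in no settled direction, is expected. Compound 4 is estimated at 10000 nM, within 3000 nM to 40000 nM. The step of a 1.2-fold higher number from compound 2 to compound 4 (0.07 log units; within the scatter) is expected to stay close to the usual scatter.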

Compound 4, half-maximal inhibitory concentration: > 100000 nM
Compound 4 was reported as a limit; the forecaster's own chance of this, stated with the estimate: 10%; middle value at least 10-fold (1.00 log units) from the limit.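

In this assay, the first change tested on this benzyl ether, nitro in place of trifluoromethyl on the aromatic carbon, gives an at least 11-fold higher number from compound 2 to compound 4 (1.06 log units; beyond the scatter). The position is therefore not indifferent to the group it carries, at least on the core of compound 2. Compound 4 stands only as a limit, so the full size of the step cannot be read: the limit of > 100000 nM in this assay, at which 2 of the 4 values shown sit.

Open, as far as these compounds go, is whether a nitrile, an amine or a carboxylic acid at this place stays near compound 2. Also open, from the compounds shown here alone, is how nitro behaves on the core of compound 1.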